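This account rests on a few compounds, and the source may have more. Where it says the series, first, only, none or still open, it means among the compounds named here.

Measured compounds:
- compound 2, `O=C(Nc1ccccc1)Nc1nc(NC2CC2)cc(Sc2c[nH]c3ccccc23)n1`: in a functional assay on PC-3 cells (Homo sapiens) for inhibition, with a stated time of 72 h (a lower number here means a stronger inhibitor, a higher number a weaker inhibitor), compound 2 gives 17500 nM
- compound 1, `Cc1cc(Cl)ccc1NC(=O)Nc1nc(Sc2c[nH]c3ccccc23)cc(N2CCN(Cc3ccccc3)CC2)n1`: in this assay compound 1 gives 22500 nM

Going by the values given here, compound 2 has the lower of the two numbers, but its only neighbour, compound 1, sits within the usual scatter of it, so the two cannot be ranked against each other; both are weak inhibitors.

The next compound, compound 3 `O=C(Nc1ccccc1)Nc1nc(Sc2c[nH]c3ccccc23)cc(N2CCN(c3ccccn3)CC2)n1`, has not yet been measured. It differs from compound 2 in a single place: 4-(pyridin-2-yl)piperazin-1-yl in place of cyclopropylamino on an aromatic carbon. Among the compounds with values here, no two measured compounds differ in only one place, so there is no measured step that shows directly what such a change does. What can be said is that compound 1, which also carries a piperazine on its core, stands within the scatter of compound 2, and that gives no hint of a large shift from this kind of group.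

The expectation is therefore a step from compound 2 to compound 3 of about a 1.0-fold higher number from compound 2 to compound 3 (0.01 log units; within the scatter), which is no change beyond the scatter, in either direction. Compound 3 is estimated at 18000 nM, with a range from 6000 nM to 50000 nM.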

Compound 3, half-maximal inhibitory concentration: 21600 nM
Beside the measured number, compound 3's estimate is 1.2-fold (0.08 log units) below it; the range from low to high includes it.
By their numbers in this assay, from the lowest: compounds 2, 3 and 1 (each within the scatter of the next).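

Going by these compounds alone, putting 4-(pyridin-2-yl)piperazin-1-yl in place of cyclopropylamino on this aromatic carbon gives the first direct reading of a change at this position: in this assay, the step is a 1.2-fold higher number from compound 2 to compound 3 (0.09 log units; within the scatter). A group of 12 heavy atoms with two rings and no hydrogen-bond donor thus takes the place of a group of 4 heavy atoms with one ring and one hydrogen-bond donor, without a step beyond the scatter, so this large exchange leaves the reading in this cell assay where it was, among weak inhibitors. No measurement shown here bears on what lies behind this result.

Going by these compounds, whether the piperazine ring or the pyridine ring on it contributes anything remains open, and an unsubstituted piperazine or a morpholine on the same carbon would help to separate the two. Also open, on these data alone, is whether a quite different group there, such as a carboxylic acid or a longer amine chain, would give a step beyond the scatter, or whether this position matters at all while the rest of the molecule stays as it is.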